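A Methoxy Group Added to the Shared Core

The source may hold more compounds than are shown below. What is called first, only, known or untested is meant among the compounds shown, and "the series" means these compounds.

Measured in a functional assay on A549 cells (Homo sapiens) for cytotoxicity, read by MTT assay, with a stated time of 48 h; a lower number here means a stronger inhibitor, a higher number a weaker inhibitor: compound 1 `CCOC(=O)c1c(-c2cc3ccccc3oc2=O)nn(-c2cccc(Cl)c2)c1C(=O)OCC` gives 28000 nM; compound 2 `CCOC(=O)c1c(-c2cc3ccccc3oc2=O)nn(-c2ccc(Cl)cc2)c1C(=O)OCC` gives 35000 nM.

For the measured compounds named here, compound 1 stands at the lowest of these two numbers, and the single measured step, a 1.3-fold higher number from compound 1 to compound 2 (0.10 log units; within the scatter), concerns only the chlorophenyl on the aromatic nitrogen. Compound 3 `CCOC(=O)c1c(-c2cc3cc(OC)ccc3oc2=O)nn(-c2cccc(Cl)c2)c1C(=O)OCC` differs from compound 1 by methoxy in place of hydrogen on an aromatic carbon. Going by the values given here, no measured step touches this part of the shared core, so nothing here points to a change in either direction. In this assay compound 3 is therefore expected to show a 1.1-fold lower number from compound 1 to compound 3 (0.03 log units; within the scatter), a step not beyond the scatter. Compound 3 is estimated at 26000 nM, within 9000 nM to 80000 nM.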

Compound 3, half-maximal inhibitory concentration: 148000 nM
For compound 3 the middle estimate is 5.7-fold (0.76 log units) below the measured one; the whole stated range lies below it.
By their numbers in this assay, from the lowest: compounds 1 and 2 (each within the scatter of the next); then compound 3.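

In this assay methoxy in place of hydrogen on an aromatic carbon of the shared core gives a 5.3-fold higher number from compound 1 to compound 3 (0.72 log units; beyond the scatter) and so moves the number beyond the scatter, which the change on the chlorophenyl did not do. This position of the core is therefore not indifferent to substitution, and here the added methoxy goes with a weaker inhibitor. No measurement at hand offers an explanation for this step. As far as these compounds go, whether a hydroxy group, a fluorine or an amine at this place would shift the number likewise stays open, as does whether methoxy acts the same way on compound 2.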